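The source may hold more compounds than are shown below. What is called first, only, known or untested is meant among the compounds shown, and "the series" means these compounds.

Measured in an assay on Sf9 cells for inhibition of protein deacetylase HDAC6 (Homo sapiens), read by fluorescence, with a stated time of 40 min; a lower number here means a stronger inhibitor, a higher number a weaker inhibitor:
compound 1 `Cc1ccc(-n2nc(-c3ccccc3)nc2CNc2ccc(C(=O)NO)cc2)cc1` — 310 nM
compound 2 `O=C(NO)c1ccc(NCc2nc(-c3ccccc3)nn2-c2ccc(Br)cc2)cc1` — 1730 nM
compound 3 `O=C(NO)c1ccc(NCc2nc(-c3ccccc3)nn2-c2ccccc2)cc1` — 112 nM

Compound 3 gives the lowest number of the three; compound 1 is nearest, separated by a 2.8-fold lower number from compound 1 to compound 3 (0.44 log units; beyond the scatter), and compound 2 furthest, separated by a 15-fold lower number from compound 2 to compound 3 (1.19 log units; beyond the scatter). Compound 4 `Cc1cccc(-n2nc(-c3ccccc3)nc2CNc2ccc(C(=O)NO)cc2)c1` differs from compound 3 by methyl in place of hydrogen on an aromatic carbon. The step that bears most directly on it is a 2.8-fold lower number from compound 1 to compound 3 (0.44 log units; beyond the scatter) read in reverse: a methyl on this ring went with a higher number, and a bromo on it with a still higher one, as a 15-fold lower number from compound 2 to compound 3 (1.19 log units; beyond the scatter) shows. Compound 4 carries its methyl at a different ring carbon from compound 1, so the size carries uncertainty. In this assay a modest rise is expected, a 2.2-fold higher number from compound 3 to compound 4 (0.35 log units; beyond the scatter). The estimate for compound 4 is 250 nM, within 100 nM to 700 nM.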

Compound 4, half-maximal inhibitory concentration: 388 nM
The estimate for compound 4 lay 1.6-fold (0.19 log units) below the measured number, and the stated range covers the measured number.
By their numbers in this assay, from the lowest: compound 3; then compounds 1 and 4 (each within the scatter of the next); then compound 2.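

In this assay, 3-methylphenyl in place of phenyl also raises the number (a 3.5-fold higher number from compound 3 to compound 4 (0.54 log units; beyond the scatter)), so the rise seen with a methyl on this ring now holds at a second ring carbon. Moving the methyl changes little between 4-methylphenyl and 3-methylphenyl (a 1.3-fold higher number from compound 1 to compound 4 (0.10 log units; within the scatter)), while 4-bromophenyl remains apart (a 4.5-fold lower number from compound 2 to compound 4 (0.65 log units; beyond the scatter)). No measurement at hand explains these steps.

On these data alone, whether an amine, a carboxylic acid or a longer chain on this ring would keep the number near that of compound 3 remains open. As far as these compounds go, the effect of a bromo at the ring carbon held by the methyl of compound 4 is also open.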